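Swapping the ring amine on the shared core

A few compounds are considered here, and "the series" means these few. Any claim that something is new, unique, unknown or untested is made for them only; others in the source may bear on it.

For the measured compounds named here, compound 2 `Clc1cccc(-c2c[nH]c3ncnc(N4CCCCC4)c23)c1` gives 48 nM in an assay for inhibition of serine/threonine-protein kinase 4 (Homo sapiens), read by luminescence and ADP-Glo, in the presence of a further agent that is not named here (a higher number here means a weaker inhibitor, a lower number a stronger inhibitor), the lower of the two numbers so far; compound 1 `CC1(O)CCN(c2ncnc3[nH]cc(-c4cccc(Cl)c4)c23)CC1` gives 145 nM, and the step of a 3.0-fold lower number from compound 1 to compound 2 (0.48 log units; beyond the scatter) shows that changing the group on this aromatic carbon shifts the result modestly. Compound 3 `Clc1cccc(-c2c[nH]c3ncnc(NCC4CC4)c23)c1` carries (cyclopropylmethyl)amino in place of piperidin-1-yl on an aromatic carbon. Going by the values given here, no measured step makes this exact change, so only the step from compound 1 to compound 2 offers guidance, and it points to a modest move at most. Compound 3 is therefore expected to change little, a 1.3-fold higher number from compound 2 to compound 3 (0.10 log units; within the scatter). The estimate for compound 3 is 60 nM, ranging from 15 nM to 250 nM.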

Compound 3, half-maximal inhibitory concentration: 140 nM
For compound 3 the middle estimate is 2.3-fold (0.37 log units) below the measured one, and the stated range covers the measured number.
By their numbers in this assay, from the lowest: compound 2; then compounds 3 and 1 (each within the scatter of the next).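

In this assay, this position responds to a change of the whole amine and not only to the substituents removed in the earlier pair: (cyclopropylmethyl)amino in place of piperidin-1-yl costs potency (a 2.9-fold higher number from compound 2 to compound 3 (0.46 log units; beyond the scatter)). Two very different groups, (cyclopropylmethyl)amino and 4-hydroxy-4-methylpiperidin-1-yl, give matching results (a 1.0-fold lower number from compound 1 to compound 3 (0.02 log units; within the scatter)), leaving the unsubstituted piperidin-1-yl of compound 2 ahead of both. No evidence here explains these differences.

From the compounds shown here alone, whether the ring or the added hydrogen-bond donor matters stays open. Dimethylamino, with neither a ring nor that donor, would help separate the two.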